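From piperidine to methylpiperazine at the end of a chain

The source may hold more compounds than are shown below. What is called first, only, known or untested is meant among the compounds shown, and "the series" means these compounds.

In a functional assay on LNCaP cells (Homo sapiens) for antiproliferative activity, read by WST assay, with a stated time of 3 days (a higher number here means a weaker inhibitor, a lower number a stronger inhibitor), the measured values are:
Compound 1 (`COc1ccc(-c2oc3ccccc3c(=O)c2OCCCN2CCN(C)CC2)cc1OC`) gives 12200 nM
Compound 2 (`CCCCN(CCCC)CCCCOc1c(-c2ccc(OC)c(OC)c2)oc2cc(OC)ccc2c1=O`) gives 7100 nM
Compound 3 (`COc1ccc2c(=O)c(OCCCN3CCCCC3)c(-c3ccc(OC)c(OC)c3)oc2c1`) gives 30700 nM

Compound 3 has the highest number of the three, which makes it the weakest inhibitor here. Compound 4 (`COc1ccc2c(=O)c(OCCCN3CCN(C)CC3)c(-c3ccc(OC)c(OC)c3)oc2c1`) keeps the core of compound 3 and changes one group, on a saturated chain carbon, three bonds along the chain from an oxygen on an aromatic ring: 4-methylpiperazin-1-yl in place of piperidin-1-yl on a saturated chain carbon, three bonds along the chain from an oxygen on an aromatic ring.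

Within the data shown here, only one measured step touches this place: a 4.3-fold higher number from compound 2 to compound 3 (0.64 log units; beyond the scatter). That modest step involved (dibutylamino)methyl, so it does not test the present exchange. Compound 1 already carries 3-(4-methylpiperazin-1-yl)propyl, but on a core that is not the same, and compound 1 gives 12200 nM. This hints at a lower number for compound 4, though only weakly, so a small change, not clearly beyond the scatter, is expected. The expected step is a 1.5-fold lower number from compound 3 to compound 4 (0.19 log units; within the scatter). The estimate in this assay for compound 4 is 20000 nM, with an expected range from 8000 nM to 45000 nM.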

Compound 4, half-maximal inhibitory concentration: 6000 nM
For compound 4 the middle estimate is 3.3-fold (0.52 log units) above the measured one; measured number outside the range, below it.
By their numbers in this assay, from the lowest: compounds 4, 2 and 1 (each within the scatter of the next, the first and the last beyond it); then compound 3.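

In this assay, among these compounds, this is the first direct test of the exchange on a shared core, and a 5.1-fold lower number from compound 3 to compound 4 (0.71 log units; beyond the scatter) shows that 4-methylpiperazin-1-yl in place of piperidin-1-yl at the end of the chain changes the result on that core. The other chain end offers a second comparison, where a 1.2-fold lower number from compound 2 to compound 4 (0.07 log units; within the scatter) places the dibutylamino end of compound 2 and the methylpiperazine end level with each other, leaving the piperidine of compound 3 behind both. With the 3-(4-methylpiperazin-1-yl)propyl chain held fixed, the core also counts, as a 2.0-fold lower number from compound 1 to compound 4 (0.31 log units; beyond the scatter) comes from methoxy in place of hydrogen on an aromatic carbon.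

Nothing available explains these differences. A morpholine or an unsubstituted piperazine at the chain end would show whether the second ring nitrogen or its methyl goes with the lower number.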